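The source may hold more compounds than are shown below. What is called first, only, known or untested is meant among the compounds shown, and "the series" means these compounds.

Measured so far:
compound 1, `Nc1scc(CN2CCN(c3cccc(C(F)(F)F)c3)CC2)c1C(=O)c1ccc(Cl)cc1`: -80%
compound 2, `Nc1scc(CN2CCC(c3ccc(Cl)cc3)CC2)c1C(=O)c1ccc(Cl)cc1`: -61%

Of the compounds shown here, two have been measured in a functional assay on CHO cells with adenosine receptor A1 (Homo sapiens) as the target, read by cAMP accumulation and immunoassay, with a stated time of 6 min, tested at 10 uM; a lower number here means a stronger effect, a higher number a weaker effect of the compound at the concentration tested. Compound 1 gives -80%, the lowest of the two numbers and therefore the stronger effect of the pair. Compound 2 gives -61%, a number that lies above compound 1 by more than the usual scatter, so compound 1 stands as the stronger of the two. The two measured compounds differ in more than one place, so no single change can be read off between them.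

Compound 3, `Nc1scc(CN2CCN(c3cccc4ccccc34)CC2)c1C(=O)c1ccc(Cl)cc1`, has not yet been measured. It is built from compound 1 by one exchange: naphthalen-1-yl in place of 3-(trifluoromethyl)phenyl on an amine nitrogen in a ring. Among the compounds with values here, both groups are of the same size and carry no donors or acceptors, and no measured pair shows what this kind of swap does here. Without such a step to lean on, the expected change from compound 1 is a number 8 percentage points higher from compound 1 to compound 3 (within the scatter), most likely nothing beyond the scatter, with a modest weakening as the more probable direction if there is one. Compound 3 is therefore expected to give about -72% in this assay, within a range from -92% to -45%.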

Compound 3, a percentage reported as activity, at one concentration (the size of the read-out at that concentration, not a potency): -21%
Beside the measured number, compound 3's estimate is 51 percentage points below it; measured number outside the range, above it.
By their numbers in this assay, from the lowest: compound 1; then compound 2; then compound 3.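

In this assay the exchange of 3-(trifluoromethyl)phenyl for naphthalen-1-yl on the amine nitrogen in the ring produces a number 59 percentage points higher from compound 1 to compound 3 (beyond the scatter) and is a large step, so this position proves highly sensitive to the choice of aromatic group. Both groups hold 10 heavy atoms and neither has hydrogen-bond donors or acceptors, so matching these counts was not enough to keep the effect; the groups still differ in that one has a single aromatic ring bearing fluorine atoms and the other has two aromatic rings of carbon only. Nothing at hand accounts for the size of this step.

As far as these compounds go, whether a plain phenyl, a 3-chlorophenyl or a naphthalen-2-yl group on the same nitrogen would stay close to compound 1 or fall towards compound 3 remains open, and such groups could show which feature of the exchange matters. Also open, from the compounds shown here alone, is whether the step would look the same at other concentrations, as each number here comes from a single concentration and is not a potency.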